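The compounds below may be only part of what the source reports. "The series", "measured", "known", "first", "only" and "open" are said of these compounds alone.

Of the compounds shown here, two from this set have been measured in a functional assay on HCT-15 cells (Homo sapiens) for cytotoxicity, read by CCK-8 assay; on this read-out higher numbers stand for weaker inhibition and lower numbers for stronger inhibition. Compound 1 `Oc1cccc(-c2cc(-c3cccs3)cc(-c3ccccc3O)n2)c1` carries a 3-hydroxyphenyl, a 2-hydroxyphenyl and a thiophen-2-yl group on the shared core. In this assay compound 1 gives > 50000 nM, which is a limit of the assay rather than a number. Compound 2 `Oc1ccccc1-c1cc(-c2ccsc2)cc(-c2ccccc2O)n1` bears two 2-hydroxyphenyl groups and a thiophen-3-yl group. In this assay compound 2 likewise reaches only a limit, at > 50000 nM. Both values shown sit at the limit of > 50000 nM in this assay, at which 2 of the 2 values shown sit, and compound 2 therefore cannot be ranked against any other compound; it stands simply as one of two members at the limit.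

Compound 3 `Oc1cccc(-c2cc(-c3ccsc3)cc(-c3ccccc3O)n2)c1` has not been measured. It differs from compound 2 in that (3-hydroxyphenyl in place of 2-hydroxyphenyl on an aromatic carbon), a 3-hydroxyphenyl in place of 2-hydroxyphenyl on an aromatic carbon. Among the measured compounds shown here, no measured pair makes this change alone, and the size of the step is unknown; with both measured compounds at the limit, no step beyond the scatter is expected in this assay, and a third value at the limit appears most likely. Compound 3 is estimated at 60000 nM, within a range from 20000 nM to 200000 nM, which is expected to mean a step that the limit leaves unreadable from compound 2 to compound 3 with no real change.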

Compound 3, half-maximal inhibitory concentration: > 50000 nM
Compound 3 was reported as a limit; the forecaster's own chance of this, stated with the estimate: 80%; the middle value lies beyond the limit too.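

In this assay no step can be read between compound 3 and either compound 2 or compound 1, because all three values are limits of the assay rather than numbers: the limit of > 50000 nM in this assay, at which 3 of the 3 values shown sit. The compounds shown leave open whether 3-hydroxyphenyl in place of 2-hydroxyphenyl, or thiophen-3-yl in place of thiophen-2-yl, changes this read-out at all.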